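The source may report more compounds than this note shows. Statements on the series, on what has been measured and on what is new or still open speak of the compounds shown alone.

In an ADME assay on MDCK cells (Canis lupus familiaris) for cytotoxicity (on this read-out higher numbers stand for lower toxicity in this test and lower numbers for higher toxicity in this test), compound 1 `O=[N+]([O-])C1=CNc2nc(-c3ccco3)nn2C1` gives 108000 nM, and compound 2 `O=[N+]([O-])C1=NNc2nc(C(F)(F)F)nn2C1c1ccc(O)cc1O` gives 108000 nM, the same reading at the digits shown. Compound 3 `O=[N+]([O-])C1=CNc2nc(-c3ccco3)nn2C1c1ccc(O)c(O)c1` has not yet been measured. It differs from compound 1 by 3,4-dihydroxyphenyl in place of hydrogen on a saturated ring carbon. Compound 2 also carries a dihydroxyphenyl group and reads 108000 nM, so only a small move toward lower numbers is expected, perhaps none beyond the scatter. The expected step is a 1.3-fold lower number from compound 1 to compound 3 (0.10 log units; within the scatter). For compound 3 the estimate is 85000 nM, with an expected range from 35000 nM to 160000 nM.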

Compound 3, half-maximal cytotoxic concentration: > 1200000 nM
Compound 3 ended at the assay's limit; the forecaster's own chance of this, stated with the estimate: 15%; at least 14-fold (1.14 log units) between middle value and limit.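

In this assay, placing 3,4-dihydroxyphenyl in place of hydrogen on this saturated ring carbon gives an at least 11-fold higher number from compound 1 to compound 3 (1.04 log units; beyond the scatter), the first step at this position among the compounds shown. The change therefore moves the read-out toward lower toxicity in this test, and clearly so. The reading for compound 3 is a limit of the assay, not a number, so the full size of the step stays unknown: the limit of > 1200000 nM in this assay, at which 1 of the 3 values shown sits.

As far as these compounds go, whether the step needs the two hydroxyl groups or the aromatic ring alone stays open. A plain phenyl or a methyl group on this carbon would separate these possibilities.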